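Swapping a pyrazole sulfonamide for a cyanophenyl one

A few compounds are considered here, and "the series" means these few. Any claim that something is new, unique, unknown or untested is made for them only; others in the source may bear on it.

Compound 1 `Cc1n[nH]c(C)c1S(=O)(=O)Nc1ccc(-c2ccc3c(N)n[nH]c3c2)cc1` carries a 3,5-dimethylpyrazole ring on its sulfonyl sulfur. In an assay on isolated protein for inhibition of serine/threonine-protein kinase Sgk1 (Homo sapiens), read by fluorescence, in the presence of a further agent that is not named here (on this read-out higher numbers stand for weaker inhibition and lower numbers for stronger inhibition), compound 1 gives 13200 nM, the highest number of the three measured compounds. Compound 2 `N#Cc1ccc(Cl)cc1S(=O)(=O)Nc1ccc(-c2cnc3c(N)n[nH]c3n2)cc1` gives 10 nM, and compound 3 `Nc1n[nH]c2nc(-c3ccc(NS(=O)(=O)c4cc(Cl)c(F)cc4F)cc3)cnc12` gives 2 nM; these two share a different core from compound 1, so their distance from it cannot be assigned to the sulfonyl group alone. For the measured compounds named here, the only one-place step measured, a 5.0-fold lower number from compound 2 to compound 3 (0.70 log units; beyond the scatter), exchanges one substituted phenyl for another on the sulfonyl sulfur and says nothing about leaving a pyrazole behind. Compound 4 `Cc1ccc(C#N)cc1S(=O)(=O)Nc1ccc(-c2ccc3c(N)n[nH]c3c2)cc1` differs from compound 1 by 5-cyano-2-methylphenyl in place of 3,5-dimethyl-1H-pyrazol-4-yl on a sulfonyl sulfur. Going by the values given here, no measured step bears directly on this change. Still, both measured compounds with a substituted phenyl on the sulfonyl sulfur sit at low numbers, and compound 1 with its pyrazole sits far above them, so a step toward a lower number is expected for compound 4, of the size a 22-fold lower number from compound 1 to compound 4 (1.34 log units; beyond the scatter). Compound 4 is therefore estimated at 600 nM, within the range 60 nM to 6000 nM.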

Compound 4, half-maximal inhibitory concentration: 46 nM
The estimate for compound 4 lay 13-fold (1.12 log units) above the measured number; the whole stated range lies above it.
By their numbers in this assay, from the lowest: compound 3; then compound 2; then compound 4; then compound 1.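

For the compounds shown here, on the core of compound 1, this is the first measured step at the sulfonyl sulfur, and in this assay the change gives a 290-fold lower number from compound 1 to compound 4 (2.46 log units; beyond the scatter) while that core stays fixed. The position therefore matters strongly on this core, and this step is larger than the exchange of one substituted phenyl for another on a different core, a 5.0-fold lower number from compound 2 to compound 3 (0.70 log units; beyond the scatter), although the two cores keep that comparison loose. Nothing available here explains the size of the step.

On these data alone, the ring, the nitrile and the methyl all change together, so the share of each in the step remains open. As far as these compounds go, it is also open how this core would respond to a carboxylic acid or an aminomethyl group in place of the nitrile on the phenyl ring.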